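The compounds below may be only part of what the source reports. "The series", "measured", "known", "first", "only" and "open" are said of these compounds alone.

Measured compounds:
compound 1, `O=C(Nc1cccc(-n2cc(-c3ccncc3)c(-c3ccc(Cl)c(O)c3)n2)c1)Nc1cccc(C(F)(F)F)c1`, in a functional assay on SF-539 cells (Homo sapiens) for inhibition, read by sulforhodamine B assay, with a stated time of 48 h (on this read-out lower numbers stand for stronger inhibition of growth and higher numbers for weaker inhibition of growth), compound 1 gives 3540 nM
compound 2, `COc1cc(-c2nn(-c3cccc(NC(=O)Nc4cc(C(F)(F)F)cc(C(F)(F)F)c4)c3)cc2-c2ccncc2)ccc1Cl`, compound 2 gives 829 nM

Compound 2 holds the lowest number of the two in this assay; compound 1 lies a good way above it, and that gap is beyond the usual scatter of repeated measurements. The two compounds differ in more than one place, so the gap cannot be pinned to a single change.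

Compound 3, `O=C(Nc1cccc(-n2cc(-c3ccncc3)c(-c3ccc(Cl)c(O)c3)n2)c1)Nc1cc(C(F)(F)F)cc(C(F)(F)F)c1`, has not yet been measured. It differs from compound 2 in one place: hydrogen in place of methyl on an oxygen on an aromatic ring. Among the compounds with values here, no measured pair isolates this change, so its size is unknown. Compound 1 also carries the 4-chloro-3-hydroxyphenyl group, but with a different partner on the urea, so it only hints that such compounds can still inhibit growth.

Compound 3 is expected to land near compound 2, with a step of a 1.4-fold higher number from compound 2 to compound 3 (0.16 log units; within the scatter) in this assay, without confidence in the direction. The estimate for compound 3 is 1200 nM, within a range from 400 nM to 4000 nM.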

Compound 3, concentration for 50% growth inhibition: 765 nM
The estimate for compound 3 lay 1.6-fold (0.20 log units) above the measured number, within the range that was stated.
By their numbers in this assay, from the lowest: compounds 3 and 2 (each within the scatter of the next); then compound 1.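

In this assay, the step from 4-chloro-3-methoxyphenyl to 4-chloro-3-hydroxyphenyl is a 1.1-fold lower number from compound 2 to compound 3 (0.03 log units; within the scatter), so at this oxygen, with this urea partner, hydrogen and methyl cannot be told apart, and the methyl is not needed to keep the growth inhibition seen with compound 2. Within the data shown here, the same pair of compounds also gives the first clean single-change comparison in the set, and the second one points elsewhere in the molecule: trifluoromethyl in place of hydrogen on an aromatic carbon of the urea partner gives a 4.6-fold lower number from compound 1 to compound 3 (0.67 log units; beyond the scatter), a modest step but a real one, which places the only clear shift so far on that side of the urea rather than at the oxygen. Nothing measured here explains either result.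

From the compounds shown here alone, whether a longer chain on that oxygen, such as ethoxy, or an amine in place of the hydroxy group would also stay close to compound 2 remains open. Going by these compounds, it is also open whether methoxy and hydroxy would read alike with the urea partner of compound 1, since each comparison here rests on a single pair.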